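Pyrazinyl in place of cyclopropylfuranyl on a thienopyrimidine amine

A few compounds are considered here, and "the series" means these few. Any claim that something is new, unique, unknown or untested is made for them only; others in the source may bear on it.

This account concerns two measured compounds and one unmeasured analogue tested in a functional assay on CHO-K1 cells for antagonist activity at adenosine receptor A1 (Homo sapiens), read by a beta-galactosidase reporter and cAMP accumulation, with stated times of 15 min and 6 h; on this read-out lower numbers stand for stronger inhibition and higher numbers for weaker inhibition. Compound 1 `Nc1nc(-c2ccc(C3CC3)o2)nc2sc(Cc3ccccc3)cc12` gives 861 nM in this assay, the higher of the two numbers. Compound 2 `COc1ccccc1Cc1cc2c(N)nc(-c3cccc(C#N)c3)nc2s1` shares the same core with compound 1 but is not a single-change partner of it; in this assay compound 2 gives 129 nM, a lower number lying beyond the usual scatter from compound 1. Compound 3 `Nc1nc(-c2cnccn2)nc2sc(Cc3ccccc3)cc12` is the unmeasured compound; it differs from compound 1 by pyrazin-2-yl in place of 5-cyclopropylfuran-2-yl on an aromatic carbon. Within the data shown here, no measured pair here isolates that change, so its effect is unknown from the data. Compound 1 already stands as the weaker of the two measured compounds, and the pyrazin-2-yl group in that place is expected to keep the number in a similar region or raise it slightly, a step of a 1.7-fold higher number from compound 1 to compound 3 (0.24 log units; within the scatter) that may sit within the scatter. Compound 3 is thus estimated at 1500 nM, with a range from 300 nM to 7000 nM.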

Compound 3, inhibition constant: 91 nM
Beside the measured number, compound 3's estimate is 16-fold (1.22 log units) above it; the measured number lies below the stated range.
By their numbers in this assay, from the lowest: compounds 3 and 2 (each within the scatter of the next); then compound 1.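

In this assay, the aromatic carbon between two ring nitrogen atoms proves sensitive to the group it carries: pyrazin-2-yl in place of 5-cyclopropylfuran-2-yl gives a 9.5-fold lower number from compound 1 to compound 3 (0.98 log units; beyond the scatter). The earlier compounds shown here could not show this, as no measured pair isolated a change at this place; the result also shows that the 5-cyclopropylfuran-2-yl group is not required for a lower number on the shared core. No measurement at hand bears on what lies behind the step.

With a single replacement shown, the compounds leave open whether the step follows from the six-membered ring or from its ring nitrogens. A phenyl or pyridin-2-yl group at this place, or a furan-2-yl group without the cyclopropyl, would help to separate these possibilities.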